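Removing One Hydroxy from Compound 3

A few compounds are considered here, and "the series" means these few. Any claim that something is new, unique, unknown or untested is made for them only; others in the source may bear on it.

In a functional assay on MSTO-211H cells (Homo sapiens) for inhibition, read by trypan blue exclusion, with a stated time of 72 h (on this read-out higher numbers stand for weaker inhibition of growth and lower numbers for stronger inhibition of growth), compound 1 `CCCn1c(-c2ccc(O)cc2)c(C)c2cc(O)ccc21` gives 2900 nM and compound 2 `Cc1c(-c2ccc(O)cc2)n(CCCCOc2ccccc2)c2ccc(O)cc12` gives 2900 nM as well. Compound 3 `Cc1c(-c2ccc(O)c(O)c2)n(CCCOc2ccccc2)c2ccc(O)cc12` has the highest number of the three (7100 nM). Compound 4 `Cc1c(-c2ccc(O)cc2)n(CCCOc2ccccc2)c2ccc(O)cc12` is still unmeasured. The structural change is hydrogen in place of hydroxy on an aromatic carbon in one place, hydrogen in place of hydroxy on an aromatic carbon, so 3,4-dihydroxyphenyl becomes 4-hydroxyphenyl, the group also found in compound 1 and compound 2. Within the data shown here, no measured step tests this change directly. The only one, phenoxymethyl in place of hydrogen on a saturated chain carbon, showed no change at the digits printed from compound 1 to compound 2 (within the scatter) when the chain changed. Compound 4 is therefore expected to fall near those two values. In this assay the expected step is a 2.4-fold lower number from compound 3 to compound 4 (0.37 log units; beyond the scatter) toward stronger inhibition of growth. Compound 4 is estimated at 3000 nM with an expected range (1300 nM to 6500 nM).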

Compound 4, concentration for 50% growth inhibition: 2400 nM
The estimate for compound 4 lay 1.3-fold (0.10 log units) above the measured number; the range from low to high includes it.
By their numbers in this assay, from the lowest: compounds 4, 1 and 2 (each within the scatter of the next); then compound 3.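

In this assay, among these compounds, the step of a 3.0-fold lower number from compound 3 to compound 4 (0.47 log units; beyond the scatter) is the first direct reading of hydrogen in place of hydroxy on this aromatic carbon, and it goes toward stronger inhibition of growth. The steps of a 1.2-fold lower number from compound 2 to compound 4 (0.08 log units; within the scatter) and a 1.2-fold lower number from compound 1 to compound 4 (0.08 log units; within the scatter) both stay within the scatter, so among these compounds only compound 3, with its 3,4-dihydroxyphenyl group, stands apart. No measurement here explains the step.

The compounds shown leave open how a methoxy group or an amine at this same aromatic carbon would read, and whether removing this hydroxy gives a similar step with a different chain on the nitrogen.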